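A few compounds are considered here, and "the series" means these few. Any claim that something is new, unique, unknown or untested is made for them only; others in the source may bear on it.

Compounds measured so far:
- Compound 1 `O=C(CCCCCCNC(=O)C(O)(O)C(F)(F)F)Nc1ccc(Cl)cc1`: 4230 nM
- Compound 2 `O=C(CCCCCCNC(=O)C(O)(O)C(F)(F)F)Nc1ccc(F)cc1F`: 18500 nM
- Compound 3 `O=C(CCCCCCNC(=O)C(O)(O)C(F)(F)F)Nc1c(F)cc(F)cc1F`: 22200 nM

In a functional assay on HCT-116 cells (Homo sapiens) for inhibition, read by colorimetric assay, with a stated time of 3 days (on this read-out higher numbers stand for weaker inhibition and lower numbers for stronger inhibition), compound 3 gives the highest of the three numbers. Its nearest neighbour is compound 2, which lies within the usual scatter of it, so no order can be read between those two. The only clear separation is to compound 1, which sits well lower, as shown by the step of a 5.2-fold higher number from compound 1 to compound 3 (0.72 log units; beyond the scatter). The related step of a 4.4-fold higher number from compound 1 to compound 2 (0.64 log units; beyond the scatter) is of similar size, while a 1.2-fold higher number from compound 2 to compound 3 (0.08 log units; within the scatter) is within the scatter.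

Compound 4 `O=C(CCCCCCNC(=O)C(O)(O)C(F)(F)F)Nc1nc2ccccc2o1` differs from compound 3 in one place: 1,3-benzoxazol-2-yl in place of 2,4,6-trifluorophenyl on an amide-type nitrogen. For the measured compounds named here, none of the measured steps touches a change of this kind; all three concern the substitution pattern on a phenyl group and not the exchange of the phenyl for a heteroaryl. The measured steps only show that altering the aromatic group on that amide-type nitrogen moves the number by a modest amount, roughly as in a 5.2-fold higher number from compound 1 to compound 3 (0.72 log units; beyond the scatter), in either direction. The expected step of a 2.5-fold lower number from compound 3 to compound 4 (0.39 log units; beyond the scatter) is therefore set as a modest one toward lower numbers, with wide uncertainty in direction. Compound 4 is estimated to give 9000 nM in this assay, within a range of 2000 nM to 35000 nM.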

Compound 4, half-maximal inhibitory concentration: 3450 nM
The estimate for compound 4 lay 2.6-fold (0.42 log units) above the measured number, and the stated range covers the measured number.
By their numbers in this assay, from the lowest: compounds 4 and 1 (each within the scatter of the next); then compounds 2 and 3 (each within the scatter of the next).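

The exchange of a fluorinated phenyl for 1,3-benzoxazol-2-yl on the amide-type nitrogen gives, in this assay, a 6.4-fold lower number from compound 3 to compound 4 (0.81 log units; beyond the scatter) and a 5.4-fold lower number from compound 2 to compound 4 (0.73 log units; beyond the scatter), which shows that this position accepts a group with a five-membered aromatic ring holding 2 hetero atoms, and that such a group can give a lower number than either fluorinated phenyl. Against the 4-chlorophenyl group, the same exchange gives a 1.2-fold lower number from compound 1 to compound 4 (0.09 log units; within the scatter), which lies within the scatter, so no order can be read between those two groups and the position does not need a phenyl to reach that level. Nothing measured here explains these steps, so their origin remains unassigned.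

Because 1,3-benzoxazol-2-yl differs from each phenyl group in its ring system, its hetero atoms and its hydrogen-bond acceptors all at once, the compounds shown cannot tell which of these features goes with the lower number. Going by these compounds, it also remains open whether a benzothiazol-2-yl or a pyridin-2-yl group on the same nitrogen would stay at this level, and whether a longer chain in the shared core would change the picture.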